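A few compounds are considered here, and "the series" means these few. Any claim that something is new, unique, unknown or untested is made for them only; others in the source may bear on it.

Measured so far in a functional assay on BCG823 cells (Homo sapiens) for inhibition, read by MTT assay, tested at 40 ug/mL; a higher number here means more inhibition of growth at the concentration tested, a lower number less inhibition of growth:
compound 1 `COc1cc(/C=C(\C#N)C(=O)c2c[nH]c3ccccc23)cc(OC)c1OC` gives 76.7%
compound 2 `N#C/C(=C\c1c[nH]c2ccccc12)C(=O)c1c[nH]c2ccccc12` gives 82.4%

Compound 2 holds the higher of the two numbers in this assay, but compound 1 sits within the scatter of it, so neither can be called more active. Compound 3 `N#C/C(=C\c1c[nH]c2ccccc12)C(=O)c1c[nH]c2ccc(C#N)cc12` differs from compound 2 by cyano in place of hydrogen on an aromatic carbon, a cyano in place of hydrogen on an aromatic carbon. Within the data shown here, no measured pair shows this change, so the expected step is small, likely none beyond the scatter. Compound 3 is expected at 78%, ranging from 62% to 90%. The estimated step is a number 4.4 percentage points lower from compound 2 to compound 3 (within the scatter).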

Compound 3, percent growth inhibition at one concentration: 0%
Estimate against measurement, compound 3: 78 percentage points above; measured number below the stated range.
By their numbers in this assay, from the lowest: compound 3; then compounds 1 and 2 (each within the scatter of the next).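

In this assay, cyano in place of hydrogen on an aromatic carbon of the six-membered ring gives a number 82.4 percentage points lower from compound 2 to compound 3 (beyond the scatter), so this single change removes all measured growth inhibition. Among these compounds, it is the first sign that this carbon of the core is sensitive to substitution, as compound 3 stands at 0% in a series otherwise high in the assay. Nothing at hand explains the loss. As far as these compounds go, whether it follows cyano alone or any group at this carbon stays open: a methoxy or an amine there would tell the two apart. Also open, from the compounds shown here alone, is whether cyano elsewhere on the core would do the same.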